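Swapping the sulfonamide aryl group: from naphthyl to carboxyphenyl

The compounds below may be only part of what the source reports. "The series", "measured", "known", "first", "only" and "open" are said of these compounds alone.

Measured compounds:
- compound 1, `COc1ccccc1NS(=O)(=O)c1ccc2nc(-c3ccccc3)c(-c3ccccc3)nc2c1`: 100%
- compound 2, `O=[N+]([O-])c1ccc(NS(=O)(=O)c2ccc3nc(-c4ccccc4)c(-c4ccccc4)nc3c2)cc1`: 87.6%
- compound 3, `O=S(=O)(Nc1cccc2ccccc12)c1ccc2nc(-c3ccccc3)c(-c3ccccc3)nc2c1`: 100%

All three share one core and differ only in the aryl group on the sulfonamide nitrogen. In an ADME assay on the whole organism for pharmacokinetics, with Homo sapiens as the target (on this read-out lower numbers stand for lower oral bioavailability and higher numbers for higher oral bioavailability), compound 3 gives 100%, level with compound 1 and together with it the highest of the three numbers; the step of a number 12.4 percentage points higher from compound 2 to compound 3 (beyond the scatter) separates it from compound 2, while no change at the digits printed from compound 1 to compound 3 (within the scatter).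

Compound 4, `O=C(O)c1ccccc1NS(=O)(=O)c1ccc2nc(-c3ccccc3)c(-c3ccccc3)nc2c1`, has not been measured. The change from compound 3 is 2-carboxyphenyl in place of naphthalen-1-yl on a sulfonamide nitrogen. Within the data shown here, no measured compound carries a carboxylic acid, so no earlier step describes this group. The steps that do touch this position, no change at the digits printed from compound 1 to compound 3 (within the scatter) and a number 12.4 percentage points higher from compound 2 to compound 3 (beyond the scatter), show that exchanging one aryl group for another moved this assay by no more than a modest amount, and compound 1 carries a 2-substituted phenyl ring with the same high number. A modest drop or no change is therefore expected, a number 12 percentage points lower from compound 3 to compound 4 (beyond the scatter). Compound 4 is estimated at 88%, between 60% and 100%.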

Compound 4, oral bioavailability: 83.6%
Beside the measured number, compound 4's estimate is 4.4 percentage points above it; measured number inside the range.
By their numbers in this assay, from the lowest: compounds 4 and 2 (each within the scatter of the next); then compounds 1 and 3 (each within the scatter of the next).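

In this assay, 2-carboxyphenyl in place of naphthalen-1-yl on the sulfonamide nitrogen gives a number 16.4 percentage points lower from compound 3 to compound 4 (beyond the scatter), and carboxy in place of methoxy on an aromatic carbon gives a number 16.4 percentage points lower from compound 1 to compound 4 (beyond the scatter). So a substituted phenyl ring does not by itself keep the top number: with carboxy in place of methoxy, the number no longer matches that of compound 1. Replacing the 4-nitrophenyl group gives a number 4 percentage points lower from compound 2 to compound 4 (within the scatter), which places these two different groups at one level, apart from the 2-methoxyphenyl and naphthalen-1-yl groups. Nothing on hand gives a reason for the drop.

A methyl ester or an amide in place of the carboxy group would show whether the drop belongs to the carboxylic acid itself. An amine on the same ring remains an open comparison.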